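Cyclopropylmethyl for Butyl: Compound 3 to Compound 4

A few compounds are considered here, and "the series" means these few. Any claim that something is new, unique, unknown or untested is made for them only; others in the source may bear on it.

Measured compounds:
compound 1, `C[C@H](c1ccc(-c2ccccc2-c2nc(=O)o[nH]2)cc1)N(CC1CC1)c1nc2c(C(=O)O)cccc2o1`: 11 nM in a functional assay on CAL1 cells for inhibition of chemerin-like receptor 1 (Homo sapiens), with a stated time of 45 min; on this read-out lower numbers stand for stronger inhibition and higher numbers for weaker inhibition
compound 2, `Cc1ccc(-c2nc(=O)o[nH]2)c(-c2ccc([C@@H](C)N(CC3CC3)c3nc4c(C(=O)O)cccc4o3)cc2)c1`: 3.2 nM in this assay
compound 3, `CCCCN(c1nc2c(C(=O)O)cccc2o1)[C@H](C)c1ccc(-c2cc(F)ccc2-c2nc(=O)o[nH]2)cc1`: 2.7 nM in this assay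

Compound 3 gives the lowest of the three numbers in this assay. Compound 2 stands nearest to it, within the scatter, while compound 1 stands furthest, beyond the scatter. For the measured compounds named here, the only single-point step among the measured compounds is a 3.4-fold lower number from compound 1 to compound 2 (0.54 log units; beyond the scatter), a methyl in place of hydrogen on an aromatic carbon; it does not touch the part of the molecule altered here. Compound 1 and compound 3 differ in two places, so their values show only a combined gap and no single step can be read from them.

Compound 4, `C[C@H](c1ccc(-c2cc(F)ccc2-c2nc(=O)o[nH]2)cc1)N(CC1CC1)c1nc2c(C(=O)O)cccc2o1`, differs from compound 3 by cyclopropyl in place of propyl on a saturated chain carbon bound to a nitrogen on an aromatic ring. Going by the values given here, no measured step bears on this exchange, so the expectation rests on the change itself: the groups leaving and entering are counted alike, with no ring opened or closed beyond the small carbon ring, and no change in donors, acceptors or charge. Compound 4 is therefore expected to stay close to compound 3, with a 1.3-fold higher number from compound 3 to compound 4 (0.11 log units; within the scatter) expected to lie within the scatter. The estimate for compound 4 in this assay is 3.5 nM, with an expected range from 1.5 nM to 8 nM.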

Compound 4, half-maximal inhibitory concentration: 2.3 nM
Compound 4: the middle estimate sits 1.5-fold (0.18 log units) above what was measured; the measured number falls inside the stated range.
By their numbers in this assay, from the lowest: compounds 4, 3 and 2 (each within the scatter of the next); then compound 1.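

In this assay, cyclopropyl in place of propyl on a saturated chain carbon bound to a nitrogen on an aromatic ring comes with a 1.2-fold lower number from compound 3 to compound 4 (0.07 log units; within the scatter), so at this position, butyl and cyclopropylmethyl cannot be told apart, even though the entering group brings a three-membered ring of carbon. With cyclopropylmethyl held fixed, fluoro in place of methyl on an aromatic carbon gives a 1.4-fold lower number from compound 2 to compound 4 (0.14 log units; within the scatter), whereas fluoro in place of hydrogen on that carbon gives a 4.8-fold lower number from compound 1 to compound 4 (0.68 log units; beyond the scatter), so fluoro and methyl cannot be separated here, while each stands apart from the hydrogen of compound 1. Nothing given here accounts for any of these steps.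

The compounds shown leave open whether an amine or a longer chain on this saturated carbon would stay as close to butyl and cyclopropylmethyl as those two stay to each other. They also leave open how a chloro or methoxy group on the aromatic carbon would compare with fluoro and methyl.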